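Replacing the Methoxycarbonyl Group at the Amine-Bearing Carbon

A few compounds are considered here, and "the series" means these few. Any claim that something is new, unique, unknown or untested is made for them only; others in the source may bear on it.

Compound 1 `CNC(=O)C(N)CCSCCCCC(=O)O` gives 8% in an assay on isolated protein for inhibition of betaine--homocysteine S-methyltransferase 1 (Homo sapiens), with a stated time of 30 min, tested at 20 uM; a higher number here means more inhibition at the concentration tested (going by the name of the read-out), a lower number less inhibition. Compound 2 `COC(=O)C(N)CCSCCCCC(=O)O` has no result in this assay: its entry reads "not determined" (no result reported), so no single number places it. Compound 3 `NC(CCSCCCCC(=O)O)c1nc(=O)o[nH]1` differs from compound 2 by a group of 6 heavy atoms (2 carbon, 2 nitrogen, 2 oxygen; one five-membered aromatic ring with 3 hetero atoms) in place of a group of 4 heavy atoms (2 carbon, 2 oxygen; no ring), on a saturated chain carbon bound to an amine nitrogen and a saturated chain carbon. Going by the values given here, no step between measured compounds is known, so the direction of this change in this assay cannot be read from the data; only a small step, within the scatter, is expected. Compound 3 is expected to give about 15%, estimated between 0% and 40%, because compound 1 gives 8%.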

Compound 3, a percentage reported as inhibition, at one concentration (the size of the read-out at that concentration, not a potency): 15%
The estimate for compound 3 equals the measured number at the digits printed, and the stated range covers the measured number.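

Going from the ring-free group to the five-membered aromatic ring with 3 hetero atoms gives a number 7 percentage points higher from compound 1 to compound 3 (within the scatter) in this assay. Going by these compounds alone, this is the first reading of a ring on this saturated chain carbon, and the read-out does not tell the two groups apart. Nothing available accounts for this result.

Where compound 2 stands against compound 3 remains open, as compound 2 has no number. Also open, going by these compounds, is how a carboxylic acid or a tetrazole on this carbon would read in this assay.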